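Diethylamino to dimethylamino on a second core

A few compounds are considered here, and "the series" means these few. Any claim that something is new, unique, unknown or untested is made for them only; others in the source may bear on it.

Compound 1 `CCN(CC)c1c(C)n(C)c(=O)n(-c2ccccc2)c1=O` and compound 2 `Cc1c(N(C)C)c(=O)n(-c2ccccc2)c(=O)n1C` share one core; compound 3 `CCN(CC)c1c(C)n(-c2ccccc2)c(=O)n(CC)c1=O` and the unmeasured compound 4 `CCn1c(=O)c(N(C)C)c(C)n(-c2ccccc2)c1=O` share another. In a physicochemical assay for lipophilicity (a lower number here means a more polar compound, a higher number a more lipophilic compound), compound 1 gives 2.11, compound 2 gives 1.3, and compound 3 gives 2.78. Compound 3 stands highest of the three measured numbers, with compound 1 nearest and compound 2 furthest, both gaps beyond the scatter.

The change from compound 1 to compound 2 is dimethylamino in place of diethylamino on an aromatic carbon. In this assay it made the step of a number 0.81 log units lower from compound 1 to compound 2 (beyond the scatter).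

The change from compound 3 to compound 4 is dimethylamino in place of diethylamino on an aromatic carbon. It is the same kind of change, not the same one: around the place, the first occurrence is meta to a methyl group (1 heavy atom), while the second is meta to an ethyl group (2 heavy atoms). The difference between the two cores is not broken down here; the two values show that compound 3 gives the higher number of the pair, beyond the scatter.

For compound 4 in this assay the expected step is a number 0.81 log units lower from compound 3 to compound 4 (beyond the scatter), set beside the earlier one, because the first occurrence of the change made a number 0.81 log units lower from compound 1 to compound 2 (beyond the scatter). Compound 4 is therefore estimated at 1.97, with the likely range running from 1.6 to 2.3.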

Compound 4, partition coefficient: 2.29
The estimate for compound 4 lay 0.32 log units below the measured number; the range from low to high includes it.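

In this assay, for the compounds shown here, the change of diethylamino to dimethylamino keeps its direction on the second core: the new step is a number 0.49 log units lower from compound 3 to compound 4 (beyond the scatter), and the earlier one is a number 0.81 log units lower from compound 1 to compound 2 (beyond the scatter), so for these four compounds the sign of the step carries from one core to the other, with no pair going against it. This does not show that the step has a fixed size that can be transferred between cores, since two occurrences are a thin basis for that, and the printed numbers are not the same; nor does it show how far the pattern extends beyond compound 1, compound 2, compound 3 and compound 4. The data offer no explanation for the two numbers differing, and whether the methyl or ethyl group on the ring nitrogen has any part in it cannot be separated here.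

Still open, on these data alone, is whether the same direction would follow along a longer chain, such as dipropylamino in the same place, or with a cyclic amine such as pyrrolidine or morpholine. Also open, as far as these compounds go, is how the step would behave on a core carrying a propyl or benzyl group in place of the methyl or ethyl group.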